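This account rests on a few compounds, and the source may have more. Where it says the series, first, only, none or still open, it means among the compounds named here.

Among the compounds with values here, compound 2 `COC(=O)C1=C(O)C[C@H](c2ccccn2)N(Cc2ccc(OC)cc2)[C@@H]1c1ccccn1` gives 29.9 uM in an ADME assay on J774.1 cells (Mus musculus) for cytotoxicity, with a stated time of 48 h (on this read-out higher numbers stand for an effect only at larger amounts of compound and lower numbers for an effect already at smaller amounts), the only plain number among the two values at hand. Compound 1 `COC(=O)C1=C(O)C[C@H](c2ccccn2)N(Cc2cccc(OC)c2)[C@@H]1c1ccccn1` reaches only a limit of this assay, > 100 uM. Within the data shown here, the one measured step, an at least 3.3-fold lower number from compound 1 to compound 2 (0.52 log units; beyond the scatter), concerns the methoxy position on the benzyl ring rather than the group itself. Compound 3 `COC(=O)C1=C(O)C[C@H](c2ccccn2)N(Cc2ccc(C)cc2)[C@@H]1c1ccccn1` differs from compound 2 by methyl in place of methoxy on an aromatic carbon. Among the measured compounds shown here, no measured step covers this exchange, so the expected change, a 1.0-fold higher number from compound 2 to compound 3 (0.00 log units; within the scatter), is within the scatter. Compound 3 is thus estimated at 30 uM, between 12 uM and 80 uM.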

Compound 3, concentration for half-maximal effect: 34.9 uM
Compound 3: the middle estimate sits 1.2-fold (0.07 log units) below what was measured; measured number inside the range.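

Methyl in place of methoxy, on an aromatic carbon para to a large group, gives a 1.2-fold higher number from compound 2 to compound 3 (0.07 log units; within the scatter), so compound 2 and compound 3 cannot be told apart in this assay. The gap to the 3-methoxyphenyl compound therefore does not depend on the methoxy group, for it remains with 4-methylphenyl: an at least 2.8-fold lower number from compound 1 to compound 3 (0.45 log units; beyond the scatter). That step is only a bound, as compound 1 stands at a limit: the limit of > 100 uM in this assay, at which 1 of the 3 values shown sits.

The compounds shown leave open whether an amine or a carboxylic acid on that aromatic carbon would leave the number where compound 2 and compound 3 stand.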